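The compounds below may be only part of what the source reports. "The series", "measured", "known", "first", "only" and "open" are said of these compounds alone.

Measured compounds:
- compound 1 `N#Cc1ccc(/N=N/c2ccc(O)c(-c3ccccc3)c2)cc1C#N`: 1120 nM
- compound 2 `COc1ccc(/N=N/c2ccc(C#N)c(C#N)c2)cc1-c1ccccc1`: 1440 nM
- compound 3 `N#Cc1ccc(/N=N/c2cc(-c3ccccc3)ccc2O)cc1C#N`: 700 nM

In an assay on isolated protein for inhibition of Amine oxidase [flavin-containing] B (Homo sapiens) (a lower number here means a stronger inhibitor, a higher number a weaker inhibitor), compound 3 gives the lowest of the three numbers; its gap to compound 1 is within the scatter, while its gap to compound 2 is beyond the scatter. Compound 4 `CC(=O)Oc1ccc(-c2ccccc2)cc1/N=N/c1ccc(C#N)c(C#N)c1` differs from compound 3 by acetyl in place of hydrogen on an oxygen on an aromatic ring. Going by the values given here, the only step that bears on capping this oxygen is a 1.3-fold higher number from compound 1 to compound 2 (0.11 log units; within the scatter), which did not move the number beyond the scatter. On that basis the step of a 1.4-fold higher number from compound 3 to compound 4 (0.15 log units; within the scatter) is expected to be small, if anything a slightly higher number, with no change beyond the scatter. Compound 4 is therefore estimated at 1000 nM, within 400 nM to 2500 nM.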

Compound 4, half-maximal inhibitory concentration: 3820 nM
Compound 4: middle estimate off by 3.8-fold (0.58 log units), on the low side; the measured number lies above the stated range.
By their numbers in this assay, from the lowest: compounds 3, 1 and 2 (each within the scatter of the next, the first and the last beyond it); then compound 4.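

In this assay, capping this oxygen is not neutral: acetyl in place of hydrogen gives a 5.5-fold higher number from compound 3 to compound 4 (0.74 log units; beyond the scatter), whereas methyl on the core of compound 1 gives a 1.3-fold higher number from compound 1 to compound 2 (0.11 log units; within the scatter). The two steps differ in both the capping group and the core, so the contrast cannot be assigned to either alone. No measured evidence bears on the origin of the acetyl step. The compounds shown leave open whether a methyl ether on the core of compound 3 would stay close to the hydroxy parent, and how a longer acyl chain such as butanoyl would compare with acetyl.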